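This account rests on a few compounds, and the source may have more. Where it says the series, first, only, none or still open, it means among the compounds named here.

Compound 1 `COc1cc(/C=C/C(=O)c2cccc(-n3cc(-c4ccccc4)[nH]c3=O)c2)ccc1O` gives 3770 nM in a functional assay on HT-29 cells (Homo sapiens) for inhibition; a higher number here means a weaker inhibitor of growth, a lower number a stronger inhibitor of growth.
Compound 2 `O=C(/C=C/c1cccc(O)c1)c1cccc(-n2cc(-c3ccccc3)[nH]c2=O)c1` gives 3330 nM in this assay.
Compound 3 `O=C(/C=C/c1cccc(O)c1)c1cccc(-n2cc(-c3ccc(Cl)cc3)[nH]c2=O)c1` gives 1900 nM in this assay.

Compound 1 has the highest number of the three in this assay; the step from it to compound 2 is a 1.1-fold lower number from compound 1 to compound 2 (0.05 log units; within the scatter), and compound 3 stands a little lower still, with both gaps within the scatter. Compound 4 `COc1ccc(-c2cn(-c3cccc(C(=O)/C=C/c4ccc(O)c(OC)c4)c3)c(=O)[nH]2)cc1` differs from compound 1 by methoxy in place of hydrogen on an aromatic carbon, on the phenyl that hangs from the shared core, para to a large group. Among the measured compounds shown here, the only measured step that bears on this position is a 1.8-fold lower number from compound 2 to compound 3 (0.24 log units; within the scatter), where chloro in place of hydrogen on the same aromatic carbon gave a small lowering that stayed within the scatter. A methoxy entering at that place is therefore expected to move this assay little, if at all, perhaps slightly downward. Compound 4 is estimated at 3000 nM, within 1500 nM to 6500 nM, which means an expected step of a 1.3-fold lower number from compound 1 to compound 4 (0.10 log units; within the scatter).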

Compound 4, concentration for 50% growth inhibition: 3840 nM
Compound 4: the middle estimate sits 1.3-fold (0.11 log units) below what was measured; the measured number falls inside the stated range.
By their numbers in this assay, from the lowest: compounds 3, 2, 1 and 4 (each within the scatter of the next, the first and the last beyond it).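

In this assay, replacing phenyl with 4-methoxyphenyl on the shared core gives a step that can barely be told from no change at all (a 1.0-fold higher number from compound 1 to compound 4 (0.01 log units; within the scatter)). This adds a second substituent at this aromatic carbon, and a first reading there with the 4-hydroxy-3-methoxyphenyl group in place: the earlier evidence was only the chloro step (a 1.8-fold lower number from compound 2 to compound 3 (0.24 log units; within the scatter)), which was made with the 3-hydroxyphenyl group present. Both steps lie within the scatter, so they set no order between methoxy and chloro at this carbon, and no supporting measurement accounts for the result.

The compounds shown leave open how an amine, a carboxylic acid or a longer chain such as butoxy would read at this carbon. They also leave open whether any group here could move the number beyond the scatter.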